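Nitro for chloro: the step from compound 2

This account rests on a few compounds, and the source may have more. Where it says the series, first, only, none or still open, it means among the compounds named here.

In a functional assay on MCF7 cells (Homo sapiens) for cytotoxicity, read by MTT assay, with a stated time of 96 h (on this read-out higher numbers stand for weaker inhibition and lower numbers for stronger inhibition), compound 1 (`COc1cc(C(=O)c2cn(-c3cccc(N)c3)cc2-c2ccccc2[N+](=O)[O-])cc(OC)c1OC`) gives 14 nM and compound 2 (`COc1cc(C(=O)c2cn(-c3ccc(N)cc3)cc2-c2ccccc2Cl)cc(OC)c1OC`) gives 83 nM as the higher number of the two, a gap beyond the scatter. Compound 3 (`COc1cc(C(=O)c2cn(-c3ccc(N)cc3)cc2-c2ccccc2[N+](=O)[O-])cc(OC)c1OC`) has nitro in place of chloro on an aromatic carbon, ortho to a large group (nitro in place of chloro on an aromatic carbon). Among the measured compounds shown here, compound 1, the only measured compound with nitro, gives 14 nM in this assay but also differs from compound 3 elsewhere, so it offers limited support for expecting a lower number. A moderate move to stronger inhibition, a 2.8-fold lower number from compound 2 to compound 3 (0.44 log units; beyond the scatter) as estimated, is expected. The expected value for compound 3 is 30 nM (estimated range 9 nM to 100 nM).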

Compound 3, half-maximal inhibitory concentration: 53 nM
For compound 3 the middle estimate is 1.8-fold (0.25 log units) below the measured one; the measured number falls inside the stated range.
By their numbers in this assay, from the lowest: compound 1; then compounds 3 and 2 (each within the scatter of the next).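

In this assay the change from 2-chlorophenyl to 2-nitrophenyl gives a 1.6-fold lower number from compound 2 to compound 3 (0.19 log units; within the scatter) and so does not separate the two compounds at this place, ortho to a large group. On the aromatic nitrogen, 4-aminophenyl in place of 3-aminophenyl gives a 3.8-fold higher number from compound 1 to compound 3 (0.58 log units; beyond the scatter) and does separate them, so the low number of compound 1 cannot be credited to nitro alone. No measurement at hand offers an explanation for either step.

As far as these compounds go, whether 3-aminophenyl has the same effect alongside 2-chlorophenyl remains open. Also open, from the compounds shown here alone, is whether a nitrile or a carboxylic acid in this place would stay level with chloro and nitro.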